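Working notes: from compound 3 to compound 4

The compounds below may be only part of what the source reports. "The series", "measured", "known", "first", "only" and "open" are said of these compounds alone.

In a functional assay on FL5.12 cells (Mus musculus) for cytotoxicity, read by flow cytometry and propidium iodide staining, with a stated time of 48 h (on this read-out higher numbers stand for weaker inhibition and lower numbers for stronger inhibition), compound 1 `CCCCCCCCc1ccc(C(=O)C[C@@H]2CCCN2)cc1` gives 2500 nM, compound 2 `CCCCCCCCc1ccc(C(=O)C[C@@H]2C[C@@H](O)CN2)cc1` gives 2100 nM and compound 3 `CCCCCCCCc1ccc(C(=O)C[C@H]2C[C@H](CO)CN2)cc1` gives 2000 nM. Compound 3 therefore stands within the scatter of both other compounds. Compound 4 `CCCCCCCCc1ccc(C(=O)CC[C@H]2C[C@H](CO)CN2)cc1` differs from it as follows: a group of 8 heavy atoms (6 carbon, 1 nitrogen, 1 oxygen; one five-membered non-aromatic ring with 1 hetero atom) in place of a group of 7 heavy atoms (5 carbon, 1 nitrogen, 1 oxygen; one five-membered non-aromatic ring with 1 hetero atom), on a saturated chain carbon bound to a carbonyl carbon. For the measured compounds named here, none of the measured steps is this same change, but all three altered the group at this place and all stayed small: a 1.2-fold lower number from compound 1 to compound 2 (0.08 log units; within the scatter), a 1.3-fold lower number from compound 1 to compound 3 (0.10 log units; within the scatter) and a 1.1-fold lower number from compound 2 to compound 3 (0.02 log units; within the scatter). On that basis, no step beyond the scatter is expected in this assay. The expected step is no change at the digits printed from compound 3 to compound 4 (within the scatter). For compound 4 the estimate is 2000 nM, with an expected range of 1000 nM to 4000 nM.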

Compound 4, half-maximal inhibitory concentration: 4000 nM
The estimate for compound 4 lay 2.0-fold (0.30 log units) below the measured number; measured number inside the range.
By their numbers in this assay, from the lowest: compounds 3, 2, 1 and 4 (each within the scatter of the next).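

In this assay the group of 8 heavy atoms, on a saturated chain carbon bound to a carbonyl carbon, gives a 2.0-fold higher number from compound 3 to compound 4 (0.30 log units; within the scatter) and also a 1.9-fold higher number from compound 2 to compound 4 (0.28 log units; within the scatter) and a 1.6-fold higher number from compound 1 to compound 4 (0.20 log units; within the scatter). This position therefore accepts a group of 8 heavy atoms without a step beyond the scatter, which compounds 1, 2 and 3 with their smaller groups could not show. No measurement available here accounts for these steps. Still open, as far as these compounds go, is whether a longer chain at this place would give a step beyond the scatter. The same holds for an amine or a carboxylic acid on the group.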